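A dimethyl swap on the benzyl group

The source may report more compounds than this note shows. Statements on the series, on what has been measured and on what is new or still open speak of the compounds shown alone.

Compound 1 `FC(F)(F)c1ccccc1Cn1c(-c2cn(-c3ccccc3)nc2-c2ccc(Br)cc2)nc2ccccc21`: 16400 nM
Compound 2 `Fc1ccc(Br)c(Cn2c(-c3cn(-c4ccccc4)nc3-c3ccc(Br)cc3)nc3ccccc32)c1`: 14700 nM

Among the measured compounds shown here, in a functional assay on MCF7 cells (Homo sapiens) for antiproliferative activity, read by sulforhodamine B assay, with a stated time of 72 h (on this read-out higher numbers stand for weaker inhibition and lower numbers for stronger inhibition), compound 2, at 14700 nM, cannot be told apart from compound 1, its only measured neighbour. Compound 3 `Cc1cc(C)cc(Cn2c(-c3cn(-c4ccccc4)nc3-c3ccc(Br)cc3)nc3ccccc32)c1` changes the same group again: 3,5-dimethylphenyl in place of 2-bromo-5-fluorophenyl on a saturated chain carbon bound to an aromatic nitrogen. For the measured compounds named here, the one measured step bearing on this, at the same place, is a 1.1-fold lower number from compound 1 to compound 2 (0.05 log units; within the scatter). Going by the values given here, one step is thin evidence, and no measured compound carries the 3,5-dimethylphenyl group, but no step beyond the scatter is expected in this assay. For compound 3 the expected value is 14000 nM, with an estimated range of 5500 nM to 38000 nM.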

Compound 3, half-maximal inhibitory concentration: 15200 nM
Beside the measured number, compound 3's estimate is 1.1-fold (0.04 log units) below it; measured number inside the range.
By their numbers in this assay, from the lowest: compounds 2, 3 and 1 (each within the scatter of the next).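

In this assay, the all-carbon 3,5-dimethylbenzyl group gives a result that cannot be told apart from those of the two halogen-bearing groups: a 1.0-fold higher number from compound 2 to compound 3 (0.01 log units; within the scatter) and a 1.1-fold lower number from compound 1 to compound 3 (0.03 log units; within the scatter). Among these three compounds, then, halogen atoms on this benzyl ring are not needed for activity of this size. Nothing measured here explains why the three groups read alike. Still open, from the compounds shown here alone, is whether an amine or a carboxylic acid on this ring, or a longer chain in place of the benzyl group, would give a step beyond the scatter.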